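Moving the propargyloxy group around the phenyl ring

The compounds below may be only part of what the source reports. "The series", "measured", "known", "first", "only" and "open" are said of these compounds alone.

Compound 3 `C#CCOc1ccc(-c2cc(-c3ccccc3OCC#C)nc(-c3ccccc3)n2)cc1` has the highest number of the three measured compounds in an assay on BTI-TN-5B1-4 cells for inhibition of Amine oxidase [flavin-containing] B (Homo sapiens), read by fluorescence and Amplex Red, using microsomes, with a stated time of 30 min (a lower number here means a stronger inhibitor, a higher number a weaker inhibitor), giving 14400 nM. Compound 1 `C#CCOc1ccc(-c2cc(-c3ccc(OCC#C)cc3)nc(-c3ccccc3)n2)cc1` gives 12300 nM, and compound 2 `C#CCOc1ccc(-c2cc(-c3cccc(OCC#C)c3)nc(C)n2)cc1` gives 8090 nM; all three lie within the scatter of one another, so none can be called stronger or weaker. Compound 4 `C#CCOc1ccc(-c2cc(-c3cccc(OCC#C)c3)nc(-c3ccccc3)n2)cc1` differs from compound 3 in one place: a group of 10 heavy atoms (9 carbon, 1 oxygen; one six-membered aromatic ring of carbon only) in place of a group of 10 heavy atoms (9 carbon, 1 oxygen; one six-membered aromatic ring of carbon only), on an aromatic carbon. Going by the values given here, the one measured step that bears on moving this group around its ring is a 1.2-fold higher number from compound 1 to compound 3 (0.07 log units; within the scatter). Compound 2, which carries the same 3-(propargyloxy)phenyl group on a core with a methyl group, gives a number near the others. No change beyond the scatter is therefore expected, and the step of a 1.3-fold lower number from compound 3 to compound 4 (0.12 log units; within the scatter) is the estimate. Compound 4 is expected to give 11000 nM, within 5000 nM to 25000 nM.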

Compound 4, half-maximal inhibitory concentration: 17700 nM
Compound 4: middle estimate off by 1.6-fold (0.21 log units), on the low side; the measured number falls inside the stated range.
By their numbers in this assay, from the lowest: compounds 2, 1, 3 and 4 (each within the scatter of the next, the first and the last beyond it).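

In this assay, the propargyloxy group has now been read at three places on its ring, and both a 1.2-fold higher number from compound 3 to compound 4 (0.09 log units; within the scatter) and a 1.4-fold higher number from compound 1 to compound 4 (0.16 log units; within the scatter) stay small, so moving it shows no real change. Going by these compounds alone, the only step that clears the scatter is a different one, phenyl in place of methyl, at a 2.2-fold higher number from compound 2 to compound 4 (0.34 log units; beyond the scatter) and modest in size. No measurement here explains these numbers. Open, from the compounds shown here alone, is whether an amine or a carboxylic acid on that phenyl ring, or a longer chain in place of propargyloxy, would shift the number.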